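The compounds below may be only part of what the source reports. "The series", "measured", "known", "first", "only" and "open" are said of these compounds alone.

Of the compounds shown here, two sharing one core have been measured in a functional assay on U-251 cells (Homo sapiens) for cytotoxicity, read by sulforhodamine B assay, with a stated time of 48 h, tested at 1 uM; a lower number here means a stronger effect, a higher number a weaker effect of the compound at the concentration tested. Compound 1 `COc1cc(C)cc(-c2c(-c3ccnc(-c4ccc(C(C)=O)cc4)c3)cnn2CC#N)c1` gives 4% in this assay. Compound 2 `COc1cc(C)cc(-c2nn(CC#N)cc2-c2ccc(-c3cccc(C(C)=O)c3)nc2)c1` gives 6% in this assay, and this number sits so close to that of compound 1 that the two cannot be told apart by this read-out. Compound 3 `COc1cc(C)cc(-c2c(-c3ccnc(-c4ccc(N(C)C)cc4)c3)cnn2CC#N)c1` has not yet been measured. It differs from compound 1 in one place: dimethylamino in place of acetyl on an aromatic carbon. Among the measured compounds shown here, no measured pair shows what this exchange does in this assay, so the size of the step is open. Both measured compounds give small numbers, that is, a strong effect at the concentration tested, and the new group could leave that effect in place or weaken it. Compound 3 is expected to give 12% in this assay, with a plausible range from 2% to 40%. That estimate means a step of a number 8 percentage points higher from compound 1 to compound 3 (within the scatter), expected to be modest and toward a weaker effect, if any.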

Compound 3, a percentage reported as activity, at one concentration (the size of the read-out at that concentration, not a potency): 6%
For compound 3 the middle estimate is 6 percentage points above the measured one; measured number inside the range.
By their numbers in this assay, from the lowest: compounds 1, 2 and 3 (each within the scatter of the next).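

In this assay the exchange of acetyl for dimethylamino on the aromatic carbon gives a number 2 percentage points higher from compound 1 to compound 3 (within the scatter) and so leaves the two compounds indistinguishable by this read-out. This is the first pair shown that differs in this one place, and it shows that, on the core of compound 1, the strong effect at the concentration tested does not require the acetyl group: the 4-(dimethylamino)phenyl compound keeps it as well. Nothing available explains why the two groups give matching numbers.

On these data alone, whether a carboxylic acid, a primary amine or a longer chain such as butyl would also keep the effect at this place remains open. As far as these compounds go, with all three compounds giving such small numbers at a single concentration, whether any of them has a stronger or weaker effect than the others at other concentrations also remains open.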